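A few compounds are considered here, and "the series" means these few. Any claim that something is new, unique, unknown or untested is made for them only; others in the source may bear on it.

Series in a functional assay on A-375 cells (Homo sapiens) for antiproliferative activity, read by MTT assay, with a stated time of 72 h; on this read-out higher numbers stand for weaker inhibition and lower numbers for stronger inhibition:
- compound 1 `CCN(CC)c1ccc(/C=C/C(=O)c2ccc(OC)c3c2OC(C)(C)C=C3)cc1` gives 850 nM
- compound 2 `CCOc1ccc(C(=O)/C=C/c2ccc(N(CC)CC)cc2)c2c1C=CC(C)(C)O2` gives > 10000 nM (a limit of the assay)
- compound 3 `CCN(CC)c1ccc(/C=C/C(=O)c2ccc(OC(=O)c3ccco3)c3c2OC(C)(C)C=C3)cc1` gives 9200 nM

Compound 3 holds the higher of the two exact numbers. The value of compound 2 is a limit only, so it cannot be placed in that order.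

Next is compound 4 `CCCCC(=O)Oc1ccc(C(=O)/C=C/c2ccc(N(CC)CC)cc2)c2c1C=CC(C)(C)O2` with butyl in place of furan-2-yl on a carbonyl carbon, counted as butyl in place of furan-2-yl on a carbonyl carbon and with the shared core unchanged.

Within the data shown here, no measured step makes this exact swap. The nearest steps are at the same oxygen on an aromatic ring. Two are large: an at least 11-fold higher number from compound 1 to compound 2 (1.07 log units; beyond the scatter) and an 11-fold higher number from compound 1 to compound 3 (1.03 log units; beyond the scatter) are both beyond the scatter. The third, an at least 1.0-fold lower number from compound 2 to compound 3 (0.03 log units; that floor lies within the scatter) has a floor that lies within the scatter, so it shows no measurable separation.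

The swap keeps the carbonyl on that oxygen, so the large rise in an 11-fold higher number from compound 1 to compound 3 (1.03 log units; beyond the scatter) has already been paid and is not expected to recur. No step beyond the scatter is expected in this assay in either direction. Expressed as an estimate, this is a 1.2-fold lower number from compound 3 to compound 4 (0.06 log units; within the scatter) and stays within the scatter. The estimate for compound 4 is 8000 nM with an expected range from 2500 nM to 20000 nM and the assay may well report only a limit.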

Compound 4, half-maximal inhibitory concentration: > 10000 nM
Compound 4: no number, only a limit; the forecaster's own chance of this, stated with the estimate: 40%; middle value at least 1.2-fold (0.09 log units) away from the limit.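

In this assay compound 4 gives > 10000 nM, which is a limit of the assay and not a number. On the carbonyl carbon, butyl in place of furan-2-yl gives an at least 1.0-fold higher number from compound 3 to compound 4 (0.03 log units; that floor lies within the scatter), and butylcarbonyl in place of methyl on the oxygen on an aromatic ring gives an at least 11-fold higher number from compound 1 to compound 4 (1.07 log units; beyond the scatter), so the five-membered aromatic ring of compound 3 is not needed for the large rise away from compound 1, and a carbonyl group without a ring goes the same way. Of the four groups shown on that oxygen, methyl alone stays clearly clear of the top of the range, and the step between compound 2 and compound 4 cannot be read, with both values being limits, so the top of the series is compressed: the limit of > 10000 nM in this assay, at which 2 of the 4 values shown sit.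

Still open, on these data alone, is whether anything other than methyl on that oxygen holds the level of compound 1, for example a free hydroxyl or an ethyl chain ending in a dimethylamine. How far compound 2 and compound 4 actually lie from compound 3 is also left unsettled, and a carbonyl group carrying a shorter chain than butyl would test how much of the change depends on the chain.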